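Swapping chloro for fluoro on an aromatic ring

The source may report more compounds than this note shows. Statements on the series, on what has been measured and on what is new or still open speak of the compounds shown alone.

Three compounds with a shared core have entries in a functional assay on the whole organism (strain BALB/c) with Mus musculus as the target, with a stated time of 4 h (a higher number here means that more compound is needed for the effect, a lower number that less compound is needed), so far. For compound 1 `CC1=C(CN2CC(C(=O)O)C2)CCc2cc(OCCC3CCCc4ccccc43)ccc21` the entry reads "not determined" (no result reported) and gives nothing to compare. Compound 2 `CC1=C(CN2CC(C(=O)O)C2)CCc2cc(OCCC3CCc4ccccc43)ccc21` shows > 1 mg/kg as its entry, which is a limit and not a number. Among the measured compounds shown here, compound 3 `CC1=C(CN2CC(C(=O)O)C2)CCc2cc(OCc3ccc(CC(C)C)cc3Cl)ccc21` gives 0.19 mg/kg as the only actual number in this set, so its standing against the others cannot be ranked.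

Compound 4 `CC1=C(CN2CC(C(=O)O)C2)CCc2cc(OCc3ccc(CC(C)C)cc3F)ccc21` carries fluoro in place of chloro on an aromatic carbon, counted as fluoro in place of chloro on an aromatic carbon in all. The swap sits ortho to a large group and meta to an isobutyl group. For the measured compounds named here, no measured pair here shows such a swap, so the expectation starts from compound 3 with its 0.19 mg/kg as the anchor. In this assay I expect no step beyond the usual scatter, with at most a slight drift towards needing more compound. The estimated change a 1.3-fold higher number from compound 3 to compound 4 (0.12 log units; within the scatter) is correspondingly small. Compound 4 is expected to give about 0.25 mg/kg (estimated range 0.08 mg/kg to 0.8 mg/kg).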

Compound 4, dose for half-maximal effect: 0.073 mg/kg
Compound 4: middle estimate off by 3.4-fold (0.53 log units), on the high side, and the stated range ends above it.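

This position is sensitive to the halogen. In this assay, fluoro in place of chloro gives a 2.6-fold lower number from compound 3 to compound 4 (0.42 log units; beyond the scatter) and so less compound is needed for the effect. Among the compounds shown here, this is the first step in the set that can be read. For the compounds shown here, it is the first pair that differs in one place only, and it shows that a small swap on this aromatic carbon, ortho to a large group and meta to an isobutyl group, can move the dose beyond the usual scatter. Nothing shown here bears on why the number falls.

The compounds shown leave open how a hydrogen, a methyl or a bromo would fare on this same carbon. They also leave open whether fluoro keeps its edge over chloro when the isobutyl group gives way to a longer chain.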